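A single-site change and its expected effect

The compounds below may be only part of what the source reports. "The series", "measured", "known", "first", "only" and "open" are said of these compounds alone.

Compound 1, `C/N=C(\S)CCn1nc(-c2ccccc2)ccc1=O`: 58.5 mg/kg
Compound 2, `N=C(S)CCN1N=C(c2cccs2)CCC1=O`: 77.3 mg/kg
Compound 3, `Cc1ccc(=S)n(CCC(=N)S)n1`: 100 mg/kg

Of the compounds shown here, three have been measured in a functional assay on the whole organism (stomach) with Rattus norvegicus as the target; a higher number here means that more compound is needed for the effect, a lower number that less compound is needed. Compound 1 gives 58.5 mg/kg, the lowest of the three numbers, yet compound 2 with 77.3 mg/kg and compound 3 with 100 mg/kg both sit within the usual scatter of it, so no order among them can be claimed.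

Compound 4, `N=C(S)CCn1nc(-c2ccccc2)ccc1=O`, has not been measured. It differs from compound 1 by a group of 3 heavy atoms (1 carbon, 1 nitrogen, 1 sulfur; no ring) in place of a group of 4 heavy atoms (2 carbon, 1 nitrogen, 1 sulfur; no ring), on a saturated chain carbon, two bonds along the chain from an aromatic nitrogen. For the measured compounds named here, no step between measured compounds involves this change, and compounds 2 and 3, which carry the entering group on differing cores, give numbers close to compound 1. The step in this assay is therefore expected to be small, at most slightly upward, and within the scatter. Compound 4 is estimated at 70 mg/kg, with a range from 35 mg/kg to 140 mg/kg, meaning an expected step of a 1.2-fold higher number from compound 1 to compound 4 (0.08 log units; within the scatter).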

Compound 4, dose for half-maximal effect: 87.3 mg/kg
Compound 4: middle estimate off by 1.2-fold (0.10 log units), on the low side; the measured number falls inside the stated range.
By their numbers in this assay, from the lowest: compounds 1, 2, 4 and 3 (each within the scatter of the next).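

In this assay, the group of 3 heavy atoms in place of the group of 4 heavy atoms gives a 1.5-fold higher number from compound 1 to compound 4 (0.17 log units; within the scatter) and so stays within the scatter. This direct comparison on the shared core shows that the swap, with 2 hydrogen-bond donors in the entering group against 1 in the leaving group, produces no readable change at this position. Nothing available explains this result. Going by these compounds, whether an amine, a carboxylic acid or a longer chain at this position would move the number beyond the scatter remains open. So does how the group of 4 heavy atoms would read on the cores of compound 2 and compound 3.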